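Replacing a 6-(hydroxycarbamoyl)hexyl Group with Hydroxy

This account rests on a few compounds, and the source may have more. Where it says the series, first, only, none or still open, it means among the compounds named here.

In a functional assay on K562 cells (Homo sapiens) for inhibition, read by trypan blue exclusion, with a stated time of 48 h (a lower number here means a stronger inhibitor, a higher number a weaker inhibitor), compound 1 `Oc1ccc(-c2ccc(-c3cc(O)cc(O)c3)cc2)cc1` gives 20000 nM as its half-maximal inhibitory concentration, while compound 2 `O=C(CCCCCCNC(=O)c1ccc(-c2ccc(-c3cc(O)cc(O)c3)cc2)cc1)NO` gives 2500 nM on the same read-out. Compound 2 thus holds the lower of the two numbers, and the gap to compound 1 lies beyond the usual scatter.

Compound 3 `O=C(NO)c1ccc(-c2ccc(-c3cc(O)cc(O)c3)cc2)cc1` has not yet been measured. It departs from compound 2 by a single change, (hydroxy in place of 6-(hydroxycarbamoyl)hexyl on an amide-type nitrogen), with hydroxy in place of 6-(hydroxycarbamoyl)hexyl on an amide-type nitrogen. Within the data shown here, no measured pair of compounds differing in one place is available, so the data do not show directly what this change does.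

Among the measured compounds shown here, the expectation therefore rests on only two values: compound 2, which carries the departing group, at 2500 nM and compound 1 at 20000 nM. A higher number, meaning a weaker inhibitor, is expected in this assay, with an estimated step of a 2.8-fold higher number from compound 2 to compound 3 (0.45 log units; beyond the scatter) and a size expected to lie beyond the scatter. For compound 3 the estimated value is 7000 nM, with a range of 2000 nM to 22000 nM expected for it.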

Compound 3, half-maximal inhibitory concentration: 20000 nM
Compound 3: middle estimate off by 2.9-fold (0.46 log units), on the low side; the measured number falls inside the stated range.
By their numbers in this assay, from the lowest: compound 2; then compounds 1 and 3 (each within the scatter of the next).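

In this assay, hydroxy in place of 6-(hydroxycarbamoyl)hexyl on the amide-type nitrogen gives an 8.0-fold higher number from compound 2 to compound 3 (0.90 log units; beyond the scatter) and so removes the advantage that compound 2 holds at this position. Hydroxycarbamoyl in place of hydroxy on an aromatic carbon gives no change at the digits printed from compound 1 to compound 3 (within the scatter) and so shows that, in this pair, hydroxycarbamoyl on the shared core does not by itself lower the number; among these compounds, the lower number goes with the full 6-(hydroxycarbamoyl)hexyl group on the amide-type nitrogen. Nothing given here explains why this group and this change behave as they do.

The compounds shown leave open how much of the difference belongs to the hexyl chain and how much to the hydroxycarbamoyl at its end, since no compound here separates the two. Also open, on these data alone, is whether a shorter or longer chain on that nitrogen would keep the lower number, and whether a carboxylic acid or an amine in place of the hydroxycarbamoyl of that chain would do the same.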